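Swapping Phenyl for Cyclohexenyl on the Alkyne Arm

The source may report more compounds than this note shows. Statements on the series, on what has been measured and on what is new or still open speak of the compounds shown alone.

Compound 1 `NC(=O)c1nc(C#Cc2ccccc2)n(COCCO)n1` was tested in an ADME assay on Huh-5-2 cells (Homo sapiens) for cytotoxicity (on this read-out higher numbers stand for lower toxicity in this test and lower numbers for higher toxicity in this test), where compound 1 gives > 50 ug/mL, which is a limit of the assay rather than a number. Compound 2 `NC(=O)c1nc(C#CC2(O)CCCC2)n(COCCO)n1` in this assay gives > 50 ug/mL, also a limit. Compound 3 `NC(=O)c1nc(C#CCCCCl)n(COCCO)n1` in this assay gives > 50 ug/mL, again a limit. None of the steps among them can be sized: a step that the two limits leave unreadable from compound 1 to compound 2, a step that the two limits leave unreadable from compound 1 to compound 3 and a step that the two limits leave unreadable from compound 2 to compound 3 all stay unreadable since (the limit of > 50 ug/mL in this assay, at which 3 of the 3 values shown sit). Compound 4 `NC(=O)c1nc(C#CC2=CCCCC2)n(COCCO)n1` differs from compound 1 by cyclohex-1-en-1-yl in place of phenyl on a triple-bonded carbon. With every neighbouring change leaving the read-out at its limit, no step beyond the scatter is expected here. The estimated step for compound 4 is a step that the limit leaves unreadable from compound 1 to compound 4. Compound 4 is therefore expected to give 80 ug/mL, between 40 ug/mL and 200 ug/mL.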

Compound 4, half-maximal cytotoxic concentration: > 50 ug/mL
Compound 4: no number, only a limit; the forecaster's own chance of this, stated with the estimate: 85%; the middle value is on the limit's open side.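

Compound 4 gives > 50 ug/mL in this assay and this is a limit. Its steps to compound 1, compound 2 and compound 3 cannot be read because all four compounds share it: the limit of > 50 ug/mL in this assay, at which 4 of the 4 values shown sit.

The compounds shown leave open whether any of these groups on the triple-bonded carbon changes the toxicity read-out at all.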